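Adding Fluorine to a Chloro-Bearing Weak Inhibitor

This account rests on a few compounds, and the source may have more. Where it says the series, first, only, none or still open, it means among the compounds named here.

Compound 1 `O=c1c(C2N=C(c3ccccc3)SS2)coc2cc(Cl)ccc12` was tested in a functional assay on IMR-32 cells (Homo sapiens) for inhibition, read by sulforhodamine B assay, with a stated time of 48 h (a higher number here means a weaker inhibitor, a lower number a stronger inhibitor), where compound 1 gives 95100 nM. Compound 2 `O=c1c(C(=S)Nc2ccccc2)coc2ccccc12` gives 95800 nM in this assay, and compound 3 `O=c1c(C(=S)Nc2ccccc2)coc2ccc(F)cc12` gives 89800 nM. The difference between the core of compound 1 and that of compound 2 is not broken down here. From compound 2 to compound 3 the change is fluoro in place of hydrogen on an aromatic carbon and the step is a 1.1-fold lower number from compound 2 to compound 3 (0.03 log units; within the scatter). Compound 4 `O=c1c(C2N=C(c3ccccc3)SS2)coc2cc(Cl)c(F)cc12` has not yet been measured; it differs from compound 1 by fluoro in place of hydrogen on an aromatic carbon, the same kind of change, although here the place is ortho to a chloro group. For the measured compounds named here, the measured step of a 1.1-fold lower number from compound 2 to compound 3 (0.03 log units; within the scatter) stayed within the scatter, and that is the only guide available. On that basis the expected step is a 1.1-fold lower number from compound 1 to compound 4 (0.03 log units; within the scatter). Compound 4 is therefore estimated at 88000 nM, with a likely range from 45000 nM to 170000 nM.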

Compound 4, half-maximal inhibitory concentration: 56800 nM
Beside the measured number, compound 4's estimate is 1.5-fold (0.19 log units) above it; low and high end bracket the measured number.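

In this assay, fluoro in place of hydrogen, ortho to a chloro group, gives a 1.7-fold lower number from compound 1 to compound 4 (0.22 log units; within the scatter). Set beside the earlier step, the change looks alike on the two cores, with no difference that stands clear of the scatter: the same change on two cores in this assay, a 1.1-fold lower number (0.03 log units; within the scatter) from compound 2 to compound 3 and a 1.7-fold lower number (0.22 log units; within the scatter) from compound 1 to compound 4, 1.6-fold (0.20 log units) apart, within the scatter of two such steps. This shows that on both cores the step stays small enough to be lost in repeat-measurement noise, but it does not show that fluoro truly lowers the number on either core, or that the same would hold on a third core.

From the compounds shown here alone, whether an amine, a carboxylic acid or a longer chain at this place would move the number beyond the scatter remains open. The same question stands for these groups on the core of compound 2.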